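Enantiomer swap at the ring stereocentre

The source may hold more compounds than are shown below. What is called first, only, known or untested is meant among the compounds shown, and "the series" means these compounds.

Compound 2 `NC(=S)N1N=C(c2ccc(F)cc2)C[C@@H]1c1ccc(Cl)cc1` gives 12 nM in an assay on mitochondria for inhibition of Amine oxidase [flavin-containing] A (Bos taurus) (on this read-out lower numbers stand for stronger inhibition and higher numbers for weaker inhibition), the higher of the two numbers shown, with compound 1 `NC(=S)N1N=C(c2ccc(F)cc2)CC1c1ccc(Cl)cc1` nearest at 6 nM. Going by the values given here, the single measured step, a 2.0-fold higher number from compound 1 to compound 2 (0.30 log units; within the scatter), rests on the fact that one of compounds 1 and 2 is drawn with a defined configuration and the other without, at the place where they differ and lies within the scatter. Compound 3 `NC(=S)N1N=C(c2ccc(F)cc2)C[C@H]1c1ccc(Cl)cc1` differs from compound 2 in that (the two compounds have the same atoms and bonds and differ only in configuration as drawn: 1 of 1 stereo elements differ; a stereocentre at a saturated ring carbon is drawn R in compound 2 and S in compound 3). The measured pair gives no sign that either drawn configuration moves this assay beyond the scatter. Compound 3 is therefore expected near 6 nM, within 2 nM to 20 nM. The expected step of a 2.0-fold lower number from compound 2 to compound 3 (0.30 log units; within the scatter) is estimated to stay close to the scatter.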

Compound 3, inhibition constant: 6 nM
Estimate against measurement, compound 3: no gap at the digits printed; the measured number falls inside the stated range.
By their numbers in this assay, from the lowest: compounds 1, 3 and 2 (each within the scatter of the next).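

Both drawn configurations at the saturated ring carbon are now available, and in this assay they differ by only a 2.0-fold lower number from compound 2 to compound 3 (0.30 log units; within the scatter). Against the form drawn without a configuration, the S form shows no change at the digits printed from compound 1 to compound 3 (within the scatter). Configuration at this position therefore produces no step beyond the scatter in this assay, for this substitution pattern. Still open, from the compounds shown here alone, is whether that holds when a carboxylic acid or an amine replaces the chlorine, since all three compounds carry the same groups. These compounds also cannot show whether configuration matters in any other assay.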